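The source may report more compounds than this note shows. Statements on the series, on what has been measured and on what is new or still open speak of the compounds shown alone.

Compound 1 `CCOC(=O)c1c(-c2cccc(Oc3ccccc3)c2)[nH]c2cc(OC)ccc2c1=O`: > 21500 nM
Compound 2 `CCOC(=O)c1c(-c2cccc(C(F)(F)F)c2)[nH]c2cc(OC)ccc2c1=O`: > 21500 nM

Both entries come from an ADME assay on Raji cells (Homo sapiens) for cytotoxicity, read by luminescence, with a stated time of 72 h (on this read-out higher numbers stand for an effect only at larger amounts of compound and lower numbers for an effect already at smaller amounts), and each is a limit rather than a number. Compound 2 stands at the limit of > 21500 nM, so it has no exact position on the scale. Compound 3 `CCOC(=O)c1c(-c2cccc(C(C)=O)c2)[nH]c2cc(OC)ccc2c1=O` has acetyl in place of trifluoromethyl on an aromatic carbon, meta to a large group: acetyl in place of trifluoromethyl on an aromatic carbon.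

Going by the values given here, only one measured step bears on this change, a step that the two limits leave unreadable from compound 1 to compound 2. It gives no size to carry over, and what the data do show is the limit of > 21500 nM in this assay, at which 2 of the 2 values shown sit. On that basis, no step beyond the usual scatter is expected in this assay in either direction, and another limit is the most likely report. The expected change is a number no higher from compound 2 to compound 3 (the limit leaves the size open). For compound 3 the estimate is 21500 nM, with an expected range from 10000 nM to 40000 nM.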

Compound 3, half-maximal effective concentration: > 21500 nM
Compound 3: a limit, no number; the forecaster's own chance of this, stated with the estimate: 85%; the middle value lies on the limit itself.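

No step can be read between compound 1, compound 2 and compound 3, since each result is a limit and not a number: the limit of > 21500 nM in this assay, at which 3 of the 3 values shown sit.

The compounds shown leave open whether phenoxy, trifluoromethyl and acetyl differ at all in their effect on these cells.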